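Difluorophenyl for Dichlorophenyl: Expected Toxicity of Compound 3

The source may hold more compounds than are shown below. What is called first, only, known or untested is meant among the compounds shown, and "the series" means these compounds.

Measured compounds:
compound 1 `COc1cc(-c2cc(/C=C/C(=O)c3ccc(Cl)c(Cl)c3)[nH]n2)cc(OC)c1OC` – 78400 nM
compound 2 `COc1ccc(-c2cc(/C=C/C(=O)c3cc(OC)c(OC)c(OC)c3)[nH]n2)cc1OC` – 5700 nM

In a functional assay on LOX IMVI cells (Homo sapiens) for inhibition, read by sulforhodamine B assay, with a stated time of 48 h (on this read-out higher numbers stand for lower toxicity in this test and lower numbers for higher toxicity in this test), compound 1 gives 78400 nM, the highest of the two numbers, so it is the less toxic of the two in this test. Compound 2 gives 5700 nM in this assay, a gap that lies beyond the usual scatter. Compound 3 `COc1cc(-c2cc(/C=C/C(=O)c3ccc(F)c(F)c3)[nH]n2)cc(OC)c1OC` has not yet been measured. It is built from compound 1 by one change: 3,4-difluorophenyl in place of 3,4-dichlorophenyl on a carbonyl carbon. Going by the values given here, no measured pair shows this exchange, so there is nothing to lean on beyond the value of compound 1 itself. The change keeps the size, shape and count of atoms of the group that is replaced, so the expected step of a 1.1-fold higher number from compound 1 to compound 3 (0.06 log units; within the scatter) is small, roughly within the scatter, with if anything a slight rise in the number. Compound 3 is therefore estimated at 90000 nM in this assay, with a plausible range from 30000 nM to 250000 nM.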

Compound 3, concentration lethal to 50% of the cells: 41500 nM
Compound 3: the middle estimate sits 2.2-fold (0.34 log units) above what was measured, and the stated range covers the measured number.
By their numbers in this assay, from the lowest: compound 2; then compounds 3 and 1 (each within the scatter of the next).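

In this assay 3,4-difluorophenyl in place of 3,4-dichlorophenyl on a carbonyl carbon gives a 1.9-fold lower number from compound 1 to compound 3 (0.28 log units; within the scatter) and so does not separate the two compounds in this test. This is the first pair shown that differs in one place, and it gives a direct reading of this position: here, the two halogen pairs cannot be told apart. Nothing measured alongside these compounds offers a reason for this result.

The compounds shown leave open whether this position would read the same with a group other than these halogen pairs, such as an unsubstituted phenyl or a phenyl bearing an amine or a carboxylic acid. They also leave open whether a phenyl carrying one chlorine or one fluorine would fall in the same range.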